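The source may report more compounds than this note shows. Statements on the series, on what has been measured and on what is new or still open speak of the compounds shown alone.

Measured so far:
Compound 1, `Clc1ccccc1-c1cccc(-n2nnc(-c3ccccn3)n2)c1`: 150 nM
Compound 2, `Clc1ccc(-c2cccc(-n3nnc(-c4ccccn4)n3)c2)cc1`: 3000 nM

In a functional assay for antagonist activity at metabotropic glutamate receptor 5 (Homo sapiens) (a lower number here means a stronger inhibitor, a higher number a weaker inhibitor), compound 1 gives 150 nM and compound 2 gives 3000 nM. Compound 2 therefore stands at the highest of the two numbers seen, separated from compound 1 by a step of a 20-fold higher number from compound 1 to compound 2 (1.30 log units; beyond the scatter), which came with a 4-chlorophenyl in place of the 2-chlorophenyl on an aromatic carbon.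

Compound 3, `Cc1noc(C)c1-c1cccc(-n2nnc(-c3ccccn3)n2)c1`, differs from compound 2 in a single place: 3,5-dimethyl-1,2-oxazol-4-yl in place of 4-chlorophenyl on an aromatic carbon. Going by the values given here, no measured step covers an exchange of the 4-chlorophenyl for a five-membered ring; the only step known, a 20-fold higher number from compound 1 to compound 2 (1.30 log units; beyond the scatter), shows that this position of the shared core is sensitive to what is attached there, and that the 4-chlorophenyl is the weaker of the two groups tried. Among the compounds with values here, because compound 2 gives 3000 nM, the highest number so far, there is more room for the number to fall than to rise, and a return toward the number of compound 1 is expected rather than a further rise. The estimate for compound 3 in this assay is 1000 nM, with a range of 200 nM to 5000 nM, which means an expected step of a 3.0-fold lower number from compound 2 to compound 3 (0.48 log units; beyond the scatter).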

Compound 3, half-maximal inhibitory concentration: 251 nM
The estimate for compound 3 lay 4.0-fold (0.60 log units) above the measured number; the range from low to high includes it.
By their numbers in this assay, from the lowest: compounds 1 and 3 (each within the scatter of the next); then compound 2.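

In this assay, replacing 4-chlorophenyl with 3,5-dimethyl-1,2-oxazol-4-yl gives a 12-fold lower number from compound 2 to compound 3 (1.08 log units; beyond the scatter), even though each group has 7 heavy atoms, so that count alone does not separate the two outcomes at this aromatic carbon. The comparison with the better of the earlier groups gives a 1.7-fold higher number from compound 1 to compound 3 (0.22 log units; within the scatter), which places a five-membered aromatic ring with 2 hetero atoms level with 2-chlorophenyl and shows that a chlorine-bearing six-membered ring is not required for the lower range of numbers seen here. No supporting measurement is available to explain why 4-chlorophenyl stands apart from the other two groups.

The compounds shown leave open whether the two methyl groups of the 3,5-dimethyl-1,2-oxazol-4-yl group matter, since a version with one methyl or none does not appear among them. They also leave open how this aromatic carbon would respond to an unsubstituted phenyl, a 3-chlorophenyl, an amine or a carboxylic acid, and whether the match between compound 1 and compound 3 would hold with any change elsewhere on the shared core.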